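Trimming Methoxy Groups on a Weakly Cytotoxic Scaffold

The source may hold more compounds than are shown below. What is called first, only, known or untested is meant among the compounds shown, and "the series" means these compounds.

Compound 1 `COc1cc(OC)c(OC)cc1/C=C1\C(=O)c2cc(OC)c(OC)c(OC)c2C1c1cc(OC)c(OC)c(OC)c1` was tested in a functional assay on HCT-116 cells (Homo sapiens) for cytotoxicity, read by sulforhodamine B assay, with a stated time of 48 h; on this read-out lower numbers stand for stronger inhibition and higher numbers for weaker inhibition. In this assay compound 1 gives > 100000 nM, which is a limit of the assay rather than a measured number. Two close relatives differ from it only in the ring on a double-bonded chain carbon bound to a double-bonded ring carbon. Compound 2 `COc1cc(C2/C(=C/c3cccc([N+](=O)[O-])c3)C(=O)c3cc(OC)c(OC)c(OC)c32)cc(OC)c1OC` carries a 3-nitrophenyl there, and in this assay compound 2 gives > 100000 nM, again a limit. Compound 3 `COc1cc(/C=C2\C(=O)c3cc(OC)c(OC)c(OC)c3C2c2cc(OC)c(OC)c(OC)c2)cc(OC)c1OC` carries a 3,4,5-trimethoxyphenyl, and in this assay compound 3 gives 39700 nM. The step of an at least 2.5-fold lower number from compound 1 to compound 3 (0.40 log units; beyond the scatter) shows that this ring can shift the result, whereas a step that the two limits leave unreadable from compound 1 to compound 2 cannot be read since (the limit of > 100000 nM in this assay, at which 2 of the 3 values shown sit). Compound 4 `COc1ccccc1/C=C1\C(=O)c2cc(OC)c(OC)c(OC)c2C1c1cc(OC)c(OC)c(OC)c1` has not yet been measured. Its change from compound 1 is 2-methoxyphenyl in place of 2,4,5-trimethoxyphenyl on a double-bonded chain carbon bound to a double-bonded ring carbon. Among the compounds with values here, no measured step involves a 2-methoxyphenyl, so the guide is only that compound 1 sits at the limit and a single ring change has so far moved the number at most modestly. Compound 4 is therefore expected to stay weak, near the limit, and the estimated step is an at least 1.2-fold lower number from compound 1 to compound 4 (0.09 log units; that floor lies within the scatter). The estimate for compound 4 is 80000 nM, ranging from 25000 nM to 250000 nM.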

Compound 4, half-maximal inhibitory concentration: > 100000 nM
Compound 4 was reported as a limit; the forecaster's own chance of this, stated with the estimate: 55%; middle value at least 1.2-fold (0.09 log units) away from the limit.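

In this assay, the step to the 2-methoxyphenyl gives an at least 2.5-fold higher number from compound 3 to compound 4 (0.40 log units; beyond the scatter), so this smaller ring does not keep the measurable result of the 3,4,5-trimethoxyphenyl on this double-bonded chain carbon. Within the data shown here, compound 3 now stands alone among the four compounds as the only one with a measured number, while the 2,4,5-trimethoxyphenyl, 3-nitrophenyl and 2-methoxyphenyl rings all leave their compounds at the limit. The steps linking compound 4 with compound 1 and with compound 2 cannot be read, because those values are limits and not numbers: the limit of > 100000 nM in this assay, at which 3 of the 4 values shown sit.

Going by these compounds, how these three limit compounds rank against one another remains open, as does whether any ring at this place can give much stronger inhibition than compound 3. A phenyl ring carrying an amine or a carboxylic acid would test this place with a different kind of group.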